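A Larger Carbamoyl Group on the Aromatic Nitrogen

A few compounds are considered here, and "the series" means these few. Any claim that something is new, unique, unknown or untested is made for them only; others in the source may bear on it.

Compound 1 `COc1cc(C(=O)NS(=O)(=O)c2ccccc2C)ccc1Cc1cn(C(F)F)c2ccc(NC(=O)OC3CCCC3)cc12` is the anchor of this comparison. Among the compounds with values here, in an assay on isolated protein for binding affinity to cysteinyl leukotriene receptor 1 (Cavia porcellus) (on this read-out higher numbers stand for weaker inhibition and lower numbers for stronger inhibition), compound 1 gives 1 nM, the highest of the two numbers measured so far. Its nearest neighbour is compound 2 `COc1cc(C(=O)NS(=O)(=O)c2ccccc2C)ccc1Cc1cn(C(=O)N(C)C)c2ccc(NC(=O)OC3CCCC3)cc12`, which in this assay gives 0.4 nM; the step of a 2.5-fold lower number from compound 1 to compound 2 (0.40 log units; beyond the scatter) is modest but lies beyond the scatter of repeated measurement. Compound 3 `CCN(CC)C(=O)n1cc(Cc2ccc(C(=O)NS(=O)(=O)c3ccccc3C)cc2OC)c2cc(NC(=O)OC3CCCC3)ccc21` has not yet been measured. It differs from compound 1 in one place: diethylcarbamoyl in place of difluoromethyl on an aromatic nitrogen. Within the data shown here, the only measured step that bears on this change is a 2.5-fold lower number from compound 1 to compound 2 (0.40 log units; beyond the scatter), in which a dimethylcarbamoyl group took the same place on the aromatic nitrogen. Compound 3 carries the diethylcarbamoyl homologue of that group, so the same direction is expected, with a size close to that step or somewhat smaller, and a result that stays within the scatter of compound 1 cannot be excluded. For compound 3 in this assay the estimate is therefore 0.5 nM, with a range from 0.2 nM to 1.5 nM. This corresponds to an expected step of a 2.0-fold lower number from compound 1 to compound 3 (0.30 log units; within the scatter).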

Compound 3, half-maximal inhibitory concentration: 0.5 nM
Compound 3: the middle estimate sits on the measured number at the digits printed; the range from low to high includes it.
By their numbers in this assay, from the lowest: compounds 2, 3 and 1 (each within the scatter of the next, the first and the last beyond it).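

On the aromatic nitrogen, diethylcarbamoyl with its 7 heavy atoms replaces difluoromethyl with its 3, and in this assay this gives a 2.0-fold lower number from compound 1 to compound 3 (0.30 log units; within the scatter), so the scatter does not separate the two compounds. Within the data shown here, the earlier pair showed only a single carbamoyl group at this position, whereas the step of diethylamino in place of dimethylamino on the carbonyl carbon, a 1.3-fold higher number from compound 2 to compound 3 (0.10 log units; within the scatter), shows that these two carbamoyl compounds cannot be told apart in this assay either. Nothing measured here accounts for these numbers or says what the carbamoyl groups do at this position.

As far as these compounds go, whether the numbers hold with a longer chain on the carbamoyl group, such as dibutylcarbamoyl, or with a ring in place of the two chains, as in morpholine-4-carbonyl, remains open. Also open, from the compounds shown here alone, is what the carbonyl itself contributes, a question that a plain propyl group on the aromatic nitrogen would address by comparison with the carbamoyl compounds.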